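Bromo in place of chloro: compound 2 to compound 3

The source may hold more compounds than are shown below. What is called first, only, known or untested is meant among the compounds shown, and "the series" means these compounds.

In a functional assay on MCF7 cells (Homo sapiens) for inhibition, read by MTT assay, with a stated time of 48 h (a higher number here means a weaker inhibitor, a lower number a stronger inhibitor), compound 1 `COc1cccc(C(c2c[nH]c3ccc(Br)cc23)c2c[nH]c3ccc(Br)cc23)c1OC` gives 89000 nM, and compound 2 `OC[C@H]1O[C@@H](n2cc(C(c3ccc(Cl)cc3)c3cn([C@@H]4O[C@H](CO)[C@@H](O)[C@H](O)[C@H]4O)c4ccc(Br)cc34)c3cc(Br)ccc32)[C@H](O)[C@@H](O)[C@@H]1O` gives 53200 nM. Among the measured compounds shown here, these two values lie within the usual scatter of each other, so compound 2 stands level with compound 1 on the only numbers available. Compound 3 `OC[C@H]1O[C@@H](n2cc(C(c3ccc(Br)cc3)c3cn([C@@H]4O[C@H](CO)[C@@H](O)[C@H](O)[C@H]4O)c4ccc(Br)cc34)c3cc(Br)ccc32)[C@H](O)[C@@H](O)[C@@H]1O` differs from compound 2 by bromo in place of chloro on an aromatic carbon. For the measured compounds named here, no measured pair shows this change, and no step beyond the scatter is expected in this assay. For compound 3 the estimate is 50000 nM, with an expected range of 25000 nM to 100000 nM.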

Compound 3, half-maximal inhibitory concentration: 51100 nM
Beside the measured number, compound 3's estimate is 1.0-fold (0.01 log units) below it, and the stated range covers the measured number.
By their numbers in this assay, from the lowest: compounds 3, 2 and 1 (each within the scatter of the next).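

In this assay, 4-chlorophenyl to 4-bromophenyl gives a 1.0-fold lower number from compound 2 to compound 3 (0.02 log units; within the scatter) and so offers the series its first matched pair: on this aromatic carbon, para to a large group, chloro and bromo stand level. That reading covers these two halogens only and says nothing about other groups at this position. No measurement available accounts for the result.

The compounds shown leave open whether an amine or a carboxylic acid on this aromatic carbon would give a step beyond the scatter. They also leave open whether a hydrogen there would stand level with the two halogens.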